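The source may report more compounds than this note shows. Statements on the series, on what has been measured and on what is new or still open speak of the compounds shown alone.

In a functional assay on the whole organism (strain Swiss albino) for inhibition, with Mus musculus as the target, in the formalin test, with a stated time of 30 min, at a dose of 100 mg/kg (on this read-out higher numbers stand for more inhibition at the one dose given (going by the name of the read-out) and lower numbers for less inhibition), compound 1 `CCN1CCc2c(c(C)nn2C(=O)Nc2ccc(F)cc2F)C1` gives 14.3%. Within the data shown here, compound 2 `CCN1CCc2c(c(C(C)(C)C)nn2C(=O)Nc2ccc(Br)cc2)C1` is built on the same shared core, and in this assay compound 2 gives 72.1%, the highest of the two numbers so far; its gap to compound 1 lies beyond the usual scatter of repeated measurements. Compound 3 `CCN1CCc2c(c(C(C)(C)C)nn2C(=O)Nc2ccc(Cl)cc2)C1` differs from compound 2 in a single place: chloro in place of bromo on an aromatic carbon. The change sits on an aromatic carbon of a six-membered aromatic ring of carbon only, para to a large group. Among the measured compounds shown here, no measured pair shows the effect of exactly this swap, so the expectation rests on compound 2 alone. Because compound 2 gives 72.1%, a step no larger than the scatter is expected, perhaps slightly downward, as a number 7.1 percentage points lower from compound 2 to compound 3 (within the scatter). Compound 3 is therefore estimated at 65%, with a likely range from 45% to 82%.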

Compound 3, a percentage reported as inhibition, in the whole organism at one dose (the size of the read-out at that dose, not a potency): 68.3%
Estimate against measurement, compound 3: 3.3 percentage points below; the measured number falls inside the stated range.
By their numbers in this assay, from the lowest: compound 1; then compounds 3 and 2 (each within the scatter of the next).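

In this assay, putting chloro in place of bromo on this aromatic carbon gives a number 3.8 percentage points lower from compound 2 to compound 3 (within the scatter), so at this place the two halogens cannot be told apart by this read-out. Among these compounds, compound 1 and compound 2 differ in more than one place, and their gap could not be tied to any one position; this pair is the first to isolate a single one. No measurement at hand explains why the two numbers lie so close.

On these data alone, with the rest of the molecule held fixed, only bromo and chloro are compared at this place, so it remains open whether a group of another kind, such as methoxy or an amine, would keep the read-out. As far as these compounds go, how much of the gap to compound 1 comes from this ring rather than from elsewhere on the molecule also stays open.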